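The compounds below may be only part of what the source reports. "The series", "measured", "known", "first", "only" and "open" are said of these compounds alone.

In an ADME assay on THP-1 cells (Homo sapiens) for cytotoxicity, read by flow cytometry and propidium iodide staining, with a stated time of 72 h (a lower number here means a stronger inhibitor, a higher number a weaker inhibitor), compound 1 `Nc1ccc2oc(-c3ccccc3)c(O)c(=O)c2c1` gives 27000 nM, while compound 2 `Nc1ccc2oc(-c3ccc(F)cc3)c(O)c(=O)c2c1` gives 4000 nM. Compound 2 therefore holds the lower of the two numbers, and the gap between them lies beyond the usual scatter. The next structure, compound 3 `Nc1ccc2oc(-c3ccc(C(F)(F)F)cc3)c(O)c(=O)c2c1`, keeps the shared core and alters a single group: it has trifluoromethyl in place of fluoro on an aromatic carbon, para to a large group (trifluoromethyl in place of fluoro on an aromatic carbon).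

Among the measured compounds shown here, only one measured step bears on this change, a 6.8-fold lower number from compound 1 to compound 2 (0.83 log units; beyond the scatter), a modest one that came with fluoro in place of hydrogen on an aromatic carbon. For the measured compounds named here, no measured compound carries trifluoromethyl, so that step is only a rough guide. It shows what happened when fluoro entered, not what happens when fluoro leaves. A small step toward a lower number is therefore expected in this assay, and it may well stay within the scatter. The estimated change is a 1.3-fold lower number from compound 2 to compound 3 (0.12 log units; within the scatter). For compound 3, the expected value is 3000 nM, with an estimated range from 900 nM to 11000 nM.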

Compound 3, half-maximal inhibitory concentration: > 125000 nM
Compound 3 gave a limit, no number; the forecaster's own chance of this, stated with the estimate: 5%; at least 41-fold (1.61 log units) between middle value and limit.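

Among the compounds shown here, until now, the only measured change on this aromatic carbon, para to a large group, pointed toward a lower number, but in this assay the same place can also move strongly the other way: trifluoromethyl in place of hydrogen gives an at least 4.6-fold higher number from compound 1 to compound 3 (0.66 log units; beyond the scatter). Trifluoromethyl in place of fluoro gives an at least 31-fold higher number from compound 2 to compound 3 (1.49 log units; beyond the scatter), so these two fluorine-bearing groups are far from interchangeable here, and the effect of fluoro says little about that of trifluoromethyl. The value of compound 3 is a limit and not a number: the limit of > 125000 nM in this assay, at which 1 of the 3 values shown sits.

The three compounds shown do not reveal what in the change from fluoro to trifluoromethyl produces this shift, since a group that differs in heavy atoms also differs in other ways that are not measured here. Chloro, methyl, methoxy or nitrile at the same place would help show whether the number climbs with any group carrying more heavy atoms than fluoro or with trifluoromethyl alone.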